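One Added Methyl Group and an Unchanged Cytotoxicity Limit

A few compounds are considered here, and "the series" means these few. Any claim that something is new, unique, unknown or untested is made for them only; others in the source may bear on it.

Four compounds share a route to cytotoxicity data. Compound 1 `O=[N+]([O-])c1cn2c(n1)OC(COc1ccc(-c3ccc(F)nc3F)nc1)CC2` and compound 2 `CC1(COc2ccc(-c3ccc(F)nc3F)nc2)CCn2cc([N+](=O)[O-])nc2O1` share one core; compound 3 `O=[N+]([O-])c1cn2c(n1)OC(COc1ccc(-c3ccc(OC(F)(F)F)cc3)cn1)CC2` and the not yet measured compound 4 `CC1(COc2ccc(-c3ccc(OC(F)(F)F)cc3)cn2)CCn2cc([N+](=O)[O-])nc2O1` share another. How the core of compound 1 and the core of compound 3 differ is not broken down here.

The read-out is an ADME assay on MRC5 cells (Homo sapiens) for cytotoxicity, read by resazurin assay, with a stated time of 72 h; a higher number here means a weaker inhibitor, a lower number a stronger inhibitor. In this assay compound 1 gives > 64000 nM, which is a limit of the assay and not a number. Compound 2 gives > 64000 nM, again a limit. Compound 3 gives > 64000 nM, also a limit.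

The change from compound 1 to compound 2 is methyl in place of hydrogen on a saturated ring carbon. Its step, a step that the two limits leave unreadable from compound 1 to compound 2, cannot be read because both values sit at the limit of > 64000 nM in this assay, at which 3 of the 3 values shown sit. The change from compound 3 to compound 4 is methyl in place of hydrogen on a saturated ring carbon, the same change at the same place as the earlier one.

With all three measured compounds at the limit of > 64000 nM in this assay, at which 3 of the 3 values shown sit, the measured pair offers no readable step to carry over; the expectation rests on the fact that adding the methyl group left compound 2 at the same limit as compound 1. The step from compound 3 to compound 4 is therefore expected to be a step that the limit leaves unreadable from compound 3 to compound 4. For compound 4 the estimated value is 80000 nM, expected to fall between 40000 nM and 200000 nM, most likely reported once more as a limit rather than a number.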

Compound 4, half-maximal inhibitory concentration: > 64000 nM
Compound 4: a limit, no number; the forecaster's own chance of this, stated with the estimate: 85%; the middle value is on the limit's open side.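

Compound 3 and compound 4 both end at a limit rather than a number in this assay, so the step between them cannot be read: the limit of > 64000 nM in this assay, at which 4 of the 4 values shown sit.

From the compounds shown here alone, with no number for any of the four compounds, it stays open whether methyl in place of hydrogen on a saturated ring carbon changes the result in this assay on either core, and at what concentration any of them would reach half-maximal inhibition.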